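Swapping Methoxy for Trifluoromethyl on the Pyrazole of Compound 1

This account rests on a few compounds, and the source may have more. Where it says the series, first, only, none or still open, it means among the compounds named here.

Measured compounds:
- compound 1, `CCCC(Oc1ccc(-n2cc(OC)cn2)cc1)c1ccc(C(=O)NCCC(=O)O)cc1`: 4400 nM
- compound 2, `O=C(O)CCNC(=O)c1ccc(C(Oc2ccc(-n3cc(C(F)(F)F)cn3)cc2)C2CC2)cc1`: 1300 nM
- compound 3, `O=C(O)CCNC(=O)c1ccc(C(Oc2ccc(-n3cc(C(F)(F)F)cn3)cc2)C2CCCC2)cc1`: 420 nM

All three were tested in an assay on cells for displacement of a labelled ligand from Glucagon receptor (Homo sapiens), in the presence of a further agent that is not named here; on this read-out higher numbers stand for weaker inhibition and lower numbers for stronger inhibition. Among them compound 1 gives the highest number; compound 2 lies nearest to it, and compound 3 gives the lowest number of the three. Going by the values given here, the only step between two compounds that differ in one place is a 3.1-fold lower number from compound 2 to compound 3 (0.49 log units; beyond the scatter), and it changes the group on the saturated chain carbon, not the pyrazole.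

Compound 4, `CCCC(Oc1ccc(-n2cc(C(F)(F)F)cn2)cc1)c1ccc(C(=O)NCCC(=O)O)cc1`, is compound 1 with one change: trifluoromethyl in place of methoxy on an aromatic carbon. Among the compounds with values here, no measured pair shows this change on its own. What the numbers do show is that both compounds carrying the trifluoromethyl, compound 2 and compound 3, give lower numbers than compound 1, though each also carries a different group on the saturated chain carbon, so the two effects cannot be separated. The propyl chain of compound 4 is kept from compound 1, and with the 4-(trifluoromethyl)-1H-pyrazol-1-yl in place of the 4-methoxy-1H-pyrazol-1-yl, a lower number beyond the scatter is expected. Compound 4 is therefore estimated at 1100 nM, between 350 nM and 3500 nM, meaning an expected 4.0-fold lower number from compound 1 to compound 4 (0.60 log units; beyond the scatter).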

Compound 4, inhibition constant: 890 nM
Compound 4: the middle estimate sits 1.2-fold (0.09 log units) above what was measured; the range from low to high includes it.
By their numbers in this assay, from the lowest: compound 3; then compounds 4 and 2 (each within the scatter of the next); then compound 1.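

In this assay, the swap on the pyrazole can now be read by itself: with the propyl chain held constant, trifluoromethyl in place of methoxy gives a step beyond the scatter (a 4.9-fold lower number from compound 1 to compound 4 (0.69 log units; beyond the scatter)), so this change lowers the number without any help from a new group on the saturated chain carbon. Compound 4 also adds propyl as a third group on that carbon with trifluoromethyl held constant, and the two comparisons differ: moving from cyclopentyl to propyl raises the number (a 2.1-fold higher number from compound 3 to compound 4 (0.33 log units; beyond the scatter)), whereas the step from cyclopropyl to propyl stays within the scatter (a 1.5-fold lower number from compound 2 to compound 4 (0.16 log units; within the scatter)), so compound 2 and compound 4 cannot be ranked. No measurement is available that explains the size of any of these steps.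

With only methoxy and trifluoromethyl shown on the pyrazole, it remains open how a nitrile or a chlorine atom would behave on that aromatic carbon. Also open, as far as these compounds go, is whether a cyclohexyl ring or a longer chain, such as butyl, on the saturated chain carbon would extend the gain seen with cyclopentyl, and whether cyclopentyl would give a similar step alongside a methoxy group on the pyrazole.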